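A few compounds are considered here, and "the series" means these few. Any claim that something is new, unique, unknown or untested is made for them only; others in the source may bear on it.

Compound 1 `O=C(/C(=C\c1ccc(I)cc1)S(=O)(=O)c1ccc(Br)cc1)c1ccc(Br)cc1` gives 1000 nM in a functional assay on DU-145 cells (Homo sapiens) for inhibition, read by trypan blue exclusion, with a stated time of 96 h; on this read-out higher numbers stand for weaker inhibition of growth and lower numbers for stronger inhibition of growth. Compound 2 `O=C(/C(=C\c1ccc(F)cc1)S(=O)(=O)c1ccc(Br)cc1)c1ccc(Br)cc1` gives 4000 nM. Compound 3 `COc1ccc(/C=C(\C(=O)c2ccc(Br)cc2)S(=O)(=O)c2ccc(Br)cc2)c(OC)c1` gives 8000 nM.

Compound 3 stands at the highest of the three numbers; compound 2 lies within the scatter of it, a 2.0-fold higher number from compound 2 to compound 3 (0.30 log units; within the scatter), while compound 1 sits further off, an 8.0-fold higher number from compound 1 to compound 3 (0.90 log units; beyond the scatter). Compound 4 `O=C(/C(=C\c1ccc(F)cc1Cl)S(=O)(=O)c1ccc(Br)cc1)c1ccc(Br)cc1` differs from compound 3 by 2-chloro-4-fluorophenyl in place of 2,4-dimethoxyphenyl on a double-bonded chain carbon bound to a double-bonded chain carbon. Within the data shown here, two steps bear on this change: a 2.0-fold higher number from compound 2 to compound 3 (0.30 log units; within the scatter) was within the scatter, and a 4.0-fold higher number from compound 1 to compound 2 (0.60 log units; beyond the scatter) was modest. Compound 4 resembles compound 2 more than it does compound 3, so a modest step toward lower numbers is expected, a 2.7-fold lower number from compound 3 to compound 4 (0.43 log units; beyond the scatter). Compound 4 is therefore estimated at 3000 nM, within 1000 nM to 10000 nM.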

Compound 4, concentration for 50% growth inhibition: 50000 nM
Compound 4: middle estimate off by 17-fold (1.22 log units), on the low side; measured number outside the range, above it.
By their numbers in this assay, from the lowest: compound 1; then compounds 2 and 3 (each within the scatter of the next); then compound 4.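

Adding a chloro on an aromatic carbon of the 4-fluorophenyl group weakens growth inhibition sharply in this assay, a 13-fold higher number from compound 2 to compound 4 (1.10 log units; beyond the scatter), a larger step than any seen earlier at this place. The swap from 2,4-dimethoxyphenyl also weakens it, a 6.3-fold higher number from compound 3 to compound 4 (0.80 log units; beyond the scatter), and the swap from 4-iodophenyl gives the widest gap, a 50-fold higher number from compound 1 to compound 4 (1.70 log units; beyond the scatter). Nothing available here explains this loss.

From the compounds shown here alone, it remains open whether chloro without the fluoro would weaken growth inhibition as much, and how a phenyl group carrying an amine or a carboxylic acid would behave at this place.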